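Replacing furan-2-yl with 4-methylphenyl in compound 3

A few compounds are considered here, and "the series" means these few. Any claim that something is new, unique, unknown or untested is made for them only; others in the source may bear on it.

Compound 1 `Cc1ccc(-c2cc(-c3ccoc3)cc(-c3ccc(Cl)s3)n2)cc1`: 17900 nM
Compound 2 `Cc1ccsc1-c1cc(-c2ccc(Cl)o2)cc(-c2ccco2)n1`: 10600 nM
Compound 3 `Clc1ccc(-c2cc(-c3ccco3)nc(-c3ccc(Cl)s3)c2)o1`: 22500 nM

All three values were measured in a functional assay on K562 cells (Homo sapiens) for cytotoxicity, read by ELISA, with a stated time of 4 days; on this read-out higher numbers stand for weaker inhibition and lower numbers for stronger inhibition. Compound 3 gives 22500 nM, a value within the scatter of that of compound 1. Among the compounds with values here, the one measured step between compounds that differ in a single place is a 2.1-fold higher number from compound 2 to compound 3 (0.33 log units; beyond the scatter), with 5-chlorothiophen-2-yl in place of 3-methylthiophen-2-yl.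

Compound 4 `Cc1ccc(-c2cc(-c3ccc(Cl)o3)cc(-c3ccc(Cl)s3)n2)cc1` has not yet been measured. Its structure departs from that of compound 3 at a different place: 4-methylphenyl in place of furan-2-yl on an aromatic carbon. The new group, 4-methylphenyl, stands in place of furan-2-yl. Within the data shown here, no measured step makes this exchange, so the one step available serves only as a modest yardstick for size. Compound 1 also carries 4-methylphenyl and 5-chlorothiophen-2-yl, and it gives 17900 nM, which lies within the scatter of the value of compound 3. No direction beyond the scatter is therefore expected in this assay. The expected change is small, a 1.2-fold lower number from compound 3 to compound 4 (0.07 log units; within the scatter). For compound 4 the estimated value is 19000 nM, with an expected range from 9000 nM to 40000 nM.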

Compound 4, half-maximal inhibitory concentration: 21400 nM
Compound 4: the middle estimate sits 1.1-fold (0.05 log units) below what was measured; the measured number falls inside the stated range.
By their numbers in this assay, from the lowest: compounds 2, 1, 4 and 3 (each within the scatter of the next, the first and the last beyond it).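

In this assay, 4-methylphenyl in place of furan-2-yl on the aromatic carbon next to the ring nitrogen gives a 1.1-fold lower number from compound 3 to compound 4 (0.02 log units; within the scatter), so with 5-chlorofuran-2-yl and 5-chlorothiophen-2-yl both present, this five-membered aromatic ring with 1 hetero atom and this six-membered aromatic ring of carbon only cannot be told apart at this place. Within the data shown here, compound 4 also opens a second comparison, with 4-methylphenyl and 5-chlorothiophen-2-yl held constant: 5-chlorofuran-2-yl in place of furan-3-yl gives a 1.2-fold higher number from compound 1 to compound 4 (0.08 log units; within the scatter), which likewise stays within the scatter, unlike the one earlier step, which lay beyond it. Nothing available accounts for either result.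

The compounds shown leave open whether the place next to the ring nitrogen would respond to a group other than an aromatic ring, such as an amine or a carboxylic acid. They also leave open whether these two exchanges would stay within the scatter on another core or outside this assay.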